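The source may hold more compounds than are shown below. What is called first, only, known or untested is meant among the compounds shown, and "the series" means these compounds.

Measured so far in a functional assay on SNB-75 cells (Homo sapiens) for cytotoxicity, read by sulforhodamine B assay, with a stated time of 24 h; on this read-out lower numbers stand for stronger inhibition of growth and higher numbers for weaker inhibition of growth:
- compound 1 `COc1ccc(C(=O)/C=C/c2cc3ccccc3[nH]c2=O)cc1`; compound 1 gives 10100 nM
- compound 2 `O=C(/C=C/c1cc2ccccc2[nH]c1=O)c1ccc(O)cc1`; compound 2 gives 23000 nM

For the measured compounds named here, compound 2 stands at the highest of the two numbers in this assay; the nearest is compound 1, and the only measured step, a 2.3-fold higher number from compound 1 to compound 2 (0.36 log units; beyond the scatter), is beyond the scatter.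

Compound 3 `O=C(/C=C/c1cc2ccccc2[nH]c1=O)c1ccc(Cl)cc1` differs from compound 2 by chloro in place of hydroxy on an aromatic carbon. Going by the values given here, the one measured step bears on it indirectly: it concerns the same oxygen, where hydrogen in place of methyl raised the number; in compound 3 that oxygen is gone entirely and chloro stands in its place. Among the compounds with values here, no measured pair shows a chloro on this ring, so direction and size rest on weak footing. The expectation is that compound 3 moves back toward the range of compound 1 rather than beyond compound 2, because the number for compound 1 is 10100 nM with no hydroxy present.

Compound 3 is therefore estimated at 12000 nM in this assay, with a range of 4000 nM to 36000 nM. This estimate means a step of a 1.9-fold lower number from compound 2 to compound 3 (0.28 log units; within the scatter), expected but not certain to lie beyond the scatter.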

Compound 3, concentration for total growth inhibition: 48800 nM
Compound 3: middle estimate off by 4.1-fold (0.61 log units), on the low side; measured number above the stated range.
By their numbers in this assay, from the lowest: compound 1; then compound 2; then compound 3.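

In this assay, chloro in place of hydroxy on this aromatic carbon weakens growth inhibition, with a 2.1-fold higher number from compound 2 to compound 3 (0.33 log units; beyond the scatter), so removing the oxygen does not bring the number back toward the lower end of the series. Chloro in place of methoxy gives the larger step, a 4.8-fold higher number from compound 1 to compound 3 (0.68 log units; beyond the scatter), which leaves compound 3 the weakest of the three and places both oxygen-bearing groups, methoxy and hydroxy, on the stronger side of chloro at this position, with no compound shown going against that order. Nothing on hand gives a reason for this ranking of the groups.

As far as these compounds go, whether the order depends on an oxygen at this carbon or on chloro itself remains open: an amine, a fluoro or a methyl group here would separate those two readings, and an ethoxy group would show whether a longer chain on the oxygen continues the trend. Also open is whether the same order holds with these groups on another carbon of this ring, or in cells other than the single line shown here.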